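A few compounds are considered here, and "the series" means these few. Any claim that something is new, unique, unknown or untested is made for them only; others in the source may bear on it.

Measured compounds in a functional assay on 1321-N1 cells for agonist activity at Free fatty acid receptor 1 (Homo sapiens), read by calcium flux, with a stated time of 0.4 s; a higher number here means a larger maximal response, a lower number a smaller maximal response:
compound 1 `C/C=C(/C)C#Cc1ccc(CCC(=O)O)c(F)c1` gives 103%
compound 2 `C/C=C\C#Cc1ccc(CCC(=O)O)c(F)c1` gives 91%
compound 3 `C/C=C(\C)C#Cc1ccc(CCC(=O)O)c(F)c1` gives 97%

Compound 3 stands second highest of the three numbers. Its nearest neighbour is compound 1, whose value lies within the scatter of it, and compound 2 also lies within the scatter of it, so no order among the three can be read with confidence.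

Compound 4 `C/C(C#Cc1ccc(CCC(=O)O)c(F)c1)=C/CO` has not been measured in this assay. It differs from compound 3 as follows: 3-hydroxy-1-methylprop-1-en-1-yl in place of 1-methylprop-1-en-1-yl on a triple-bonded carbon

Within the data shown here, three measured steps bear on this change, all at the same place on the triple-bonded carbon. Between compound 1 and compound 3 only the drawn configuration differs, and there a number 6 percentage points lower from compound 1 to compound 3 (within the scatter); this is known because of the fact that compounds 1 and 3 differ only in the configuration as drawn. The step of a number 6 percentage points higher from compound 2 to compound 3 (within the scatter) also stays within the scatter. Among the measured compounds shown here, only the step of a number 12 percentage points lower from compound 1 to compound 2 (beyond the scatter) goes beyond it, and even that is modest. None of these steps brings in a hydroxyl, so they bear on the change to compound 4 only loosely. Compound 4 is therefore expected to show little change, with a number 7 percentage points lower from compound 3 to compound 4 (within the scatter) as the estimated step. Compound 4 is expected to give about 90%, with a range from 65% to 108%.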

Compound 4, largest response reached (reported as efficacy), in percent of the reference or control that the assay uses: 105%
Compound 4: middle estimate off by 15 percentage points, on the low side; measured number inside the range.
By their numbers in this assay, from the lowest: compounds 2, 3, 1 and 4 (each within the scatter of the next, the first and the last beyond it).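

Compound 4 is the only one of these compounds with a hydroxy group at this place on the triple-bonded carbon, and in this assay the group is tolerated. The most direct comparison, hydroxy in place of hydrogen on a saturated chain carbon bound to a double-bonded chain carbon, gives a number 2 percentage points higher from compound 1 to compound 4 (within the scatter), so the maximal response holds with the added donor and acceptor. Against compound 3 the new group gives a number 8 percentage points higher from compound 3 to compound 4 (within the scatter), and against compound 2, which lacks both the methyl and the hydroxy, it gives a number 14 percentage points higher from compound 2 to compound 4 (beyond the scatter), the only one of the three new steps beyond the scatter; the first of these comparisons also carries a difference in drawn configuration, which follows from this: the fact that compounds 1 and 3 differ only in the configuration as drawn.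

From the compounds shown here alone, how a methyl ether, an amine or a carboxylic acid in place of this hydroxy, or a longer chain carrying it, would read in this assay stays open, as does the hydroxy group on the drawn configuration of compound 3. The maximal responses shown also leave open whether the hydroxy group changes potency at this receptor.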